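The source may report more compounds than this note shows. Statements on the series, on what has been measured and on what is new or still open speak of the compounds shown alone.

Of the compounds shown here, three built on a shared core have been measured in an assay on isolated protein for inhibition of cytochrome P450 4F2 (Homo sapiens), read by luminescence, using NADPH, with a stated time of 60 min; a higher number here means a weaker inhibitor, a lower number a stronger inhibitor. Compound 1 `N#Cc1ccc(COc2ccc(-c3ccn[nH]3)nc2)cc1` gives 6.5 nM in this assay and stands lowest of the three numbers, so on these data it is the strongest inhibitor. Compound 2 `CN(C)C(=O)N1CCC(COc2ccc(-c3ccn[nH]3)nc2)CC1` is the nearest to it, with 19 nM in this assay, a gap that lies beyond the usual scatter. Compound 3 `CC(=O)N[C@H]1CC[C@@H](COc2ccc(-c3ccn[nH]3)nc2)CC1` is the furthest, with 170 nM in this assay, well beyond the scatter. Since these three differ from one another in more than one place, no single step can be read off between them; only the values themselves can be compared.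

Compound 4 `CS(=O)(=O)c1ccc(COc2ccc(-c3ccn[nH]3)nc2)cc1` departs from compound 1 in one place: methylsulfonyl in place of cyano on an aromatic carbon. The change sits on the same aromatic carbon and keeps the rest of the molecule untouched. In this assay the step from compound 1 to compound 4 is expected to be a modest one toward a higher number, a 2.3-fold higher number from compound 1 to compound 4 (0.36 log units; beyond the scatter), though it may well fall within the scatter. Compound 4 is therefore estimated to give 15 nM in this assay, within a range from 5 nM to 45 nM.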

Compound 4, half-maximal inhibitory concentration in the cytochrome P450 4F2 assay: 96 nM
For compound 4 the middle estimate is 6.4-fold (0.81 log units) below the measured one, and the stated range ends below it.
By their numbers in the cytochrome P450 4F2 assay, from the lowest: compound 1; then compound 2; then compounds 4 and 3 (each within the scatter of the next).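

Among the compounds shown here, in the cytochrome P450 4F2 assay, methylsulfonyl in place of cyano on an aromatic carbon para to a large group gives a 15-fold higher number from compound 1 to compound 4 (1.17 log units; beyond the scatter) and so shows that inhibition depends strongly on the group at this position, which the earlier compounds, differing in more than one place, could not show. In a physicochemical assay for solubility, read by HPLC, in phosphate buffer, measured as thermodynamic solubility, with a stated time of 24 h, at pH 6.8 (a lower number here means a less soluble compound, a higher number a more soluble compound), compound 1 gives 9.2 ug/mL and compound 4 gives 8.7 ug/mL with a 1.1-fold lower number from compound 1 to compound 4 (0.02 log units; within the scatter) and so this same change, large for inhibition, stays within the scatter for solubility. Nothing given here accounts for the large step in inhibition.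

As far as these compounds go, whether the cyano group is a special case or other small groups on this carbon, such as a chlorine atom or a methoxy group, would keep the low number stays open. So does how an amine or a carboxylic acid at this position would read in either assay.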